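Hydroxymethylphenyl replacing chlorofluorophenyl on the aryl hydrazone arm

A few compounds are considered here, and "the series" means these few. Any claim that something is new, unique, unknown or untested is made for them only; others in the source may bear on it.

Compound 1 `O=C1Nc2ccc(Br)cc2/C1=N/NC(=S)N/N=C/c1c(F)cccc1Cl` gives 2560 nM in a functional assay on COS-7 cells (Chlorocebus aethiops) for inhibition, read by MTT assay; on this read-out lower numbers stand for stronger inhibition and higher numbers for weaker inhibition. Compound 3 `COc1ccc(/C=N/NC(=S)N/N=C2\C(=O)Nc3ccc(C)cc32)cc1O` gives 3190 nM in this assay, a number within the usual scatter of that of compound 1. Compound 2 `O=C1Nc2ccc(Br)cc2/C1=N/NC(=S)N/N=C/c1ccccc1Br` reaches only a limit of this assay, > 50000 nM, which is the limit of > 50000 nM in this assay, at which 1 of the 3 values shown sits. Among the measured compounds shown here, the one single-point step known, an at least 19-fold higher number from compound 1 to compound 2 (1.29 log units; beyond the scatter), shows that replacing the aryl group on the carbon with a double bond to nitrogen can move the number far beyond the scatter.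

Compound 4 `Cc1ccc(O)c(/C=N/NC(=S)N/N=C2\C(=O)Nc3ccc(Br)cc32)c1` differs from compound 1 by 2-hydroxy-5-methylphenyl in place of 2-chloro-6-fluorophenyl on a carbon with a double bond to nitrogen. For the measured compounds named here, no measured step matches this exact change. The step from compound 1 to compound 2 bears on it in kind, as a change of the same aryl group, and was large; compound 3, which carries a hydroxy-bearing aryl on this carbon together with a different core, gives a number close to that of compound 1. The expected step of a 1.6-fold higher number from compound 1 to compound 4 (0.19 log units; within the scatter) is therefore small, with wide uncertainty, and compound 4 is estimated at 4000 nM in this assay, within 1300 nM to 25000 nM.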

Compound 4, half-maximal inhibitory concentration: > 50000 nM
Compound 4: a limit, no number; the forecaster's own chance of this, stated with the estimate: 20%; middle value at least 12-fold (1.09 log units) from the limit.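

Placing 2-hydroxy-5-methylphenyl on the carbon with a double bond to nitrogen gives an at least 19-fold higher number from compound 1 to compound 4 (1.29 log units; beyond the scatter) in this assay and thus shows that the large step at this position is not confined to 2-bromophenyl. On this shared core, 2-chloro-6-fluorophenyl is the only one of the three aryl groups shown that gives a number rather than a limit: the limit of > 50000 nM in this assay, at which 2 of the 4 values shown sit. Compound 2 and compound 4 both stand at limits, so the step between them cannot be read.

The compounds shown do not separate the hydroxy group from the methyl group of 2-hydroxy-5-methylphenyl as the source of the step. Also open, from the compounds shown here alone, is whether an aryl group on this carbon carrying an amine or a carboxylic acid would give a number on this core.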